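This account rests on a few compounds, and the source may have more. Where it says the series, first, only, none or still open, it means among the compounds named here.

In a functional assay on SW-620 cells (Homo sapiens) for antiproliferative activity, read by MTT assay, with a stated time of 72 h (a higher number here means a weaker inhibitor, a lower number a stronger inhibitor), three compounds have been read so far. Compound 1 `Cc1ccc(-c2cn(C/C=C3\OC(=O)C(OCc4ccccc4)=C3OCc3ccccc3)nn2)cc1` gives > 100000 nM as a limit of the assay and not a number. Compound 2 `O=C1O[C@H]([C@@H](O)Cn2cc(-c3cccc(O)c3)nn2)C(OCc2ccccc2)=C1OCc1ccccc1` gives > 100000 nM as a limit too. Compound 3 `O=C1O/C(=C\Cn2cc(-c3cc(C(F)(F)F)cc(C(F)(F)F)c3)nn2)C(OCc2ccccc2)=C1OCc1ccccc1` gives > 100000 nM as a limit again. Compound 2 therefore has no numerical standing and shares the limit of > 100000 nM in this assay, at which 3 of the 3 values shown sit, with the other two. Compound 4 `CC(C)(C)c1cn(C[C@H](O)[C@H]2OC(=O)C(OCc3ccccc3)=C2OCc2ccccc2)nn1` differs from compound 2 in one place: tert-butyl in place of 3-hydroxyphenyl on an aromatic carbon with the rest of the structure shared. Among the compounds with values here, no measured step guides this change, so no shift beyond the scatter is expected. The expected step is a number no higher from compound 2 to compound 4 (the limit leaves the size open) on this estimate. For compound 4 the estimated value is 100000 nM with an expected range from 40000 nM to 250000 nM in this reading.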

Compound 4, half-maximal inhibitory concentration: 35800 nM
Compound 4: middle estimate off by 2.8-fold (0.45 log units), on the high side; measured number below the stated range.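

In this assay, within the data shown here, the aromatic carbon of the five-membered ring gives the first number of the series: tert-butyl in place of 3-hydroxyphenyl brings an at least 2.7-fold lower number from compound 2 to compound 4 (0.44 log units; beyond the scatter). The position therefore does not hold every compound at the limit, and a group with no ring can read measurably here. Compound 4 is the only compound shown to leave that limit: the limit of > 100000 nM in this assay, at which 3 of the 4 values shown sit.

Tert-butyl removes the aromatic ring and the hydroxyl together, so the compounds shown do not separate the two. From the compounds shown here alone, whether a longer alkyl chain, a cyclohexyl ring or an amine at this carbon would give a lower number also stays open.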